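Replacing the carbamoyl with a benzyl ether on the core

The source may report more compounds than this note shows. Statements on the series, on what has been measured and on what is new or still open speak of the compounds shown alone.

Compound 2 `Cc1nn(-c2ncnc3nc[nH]c23)c2c1C(C(=O)N(C)c1ccccc1)CC(=O)N2` carries a methyl(phenyl)carbamoyl group on the saturated ring carbon of the shared core. Within the data shown here, in a functional assay on HEK293 cells for agonist activity at G-protein coupled receptor 39 (Homo sapiens), read by scintillation proximity assay and inositol phosphate accumulation, with a stated time of 75 min (on this read-out higher numbers stand for an effect only at larger amounts of compound and lower numbers for an effect already at smaller amounts), compound 2 gives 5220 nM, the highest of the two numbers measured so far. Its nearest neighbour, compound 1 `Cc1nn(-c2ncnc3nc[nH]c23)c2c1C(NC(=O)Cc1cccs1)CC(=O)N2`, gives 244 nM in the same assay, and the step of a 21-fold higher number from compound 1 to compound 2 (1.33 log units; beyond the scatter) shows how strongly this position answers to what sits on it. Compound 3 `Cc1nn(-c2ncnc3nc[nH]c23)c2c1C(OCc1ccc(C#N)cc1)CC(=O)N2` is the next member: (4-cyanobenzyl)oxy in place of methyl(phenyl)carbamoyl on a saturated ring carbon. Among the measured compounds shown here, only that single step bears on the new change, and it was large, so a substantial move in either direction is possible; compound 2 already stands at the high end of the two numbers, which leaves more room downward than upward. The step is therefore expected to be a 3.5-fold lower number from compound 2 to compound 3 (0.54 log units; beyond the scatter). Compound 3 is estimated at 1500 nM, within a range of 300 nM to 8000 nM.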

Compound 3, half-maximal effective concentration: 60 nM
Compound 3: middle estimate off by 25-fold (1.40 log units), on the high side; the whole stated range lies above it.
By their numbers in this assay, from the lowest: compound 3; then compound 1; then compound 2.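

In this assay, (4-cyanobenzyl)oxy in place of methyl(phenyl)carbamoyl gives an 87-fold lower number from compound 2 to compound 3 (1.94 log units; beyond the scatter) even though both groups have the same number of heavy atoms and one six-membered aromatic ring of carbon only, so matching in these counts does not make two groups equivalent on this saturated ring carbon. The same ether also gives a 4.1-fold lower number from compound 1 to compound 3 (0.61 log units; beyond the scatter) and so goes beyond the amide of compound 1, making compound 3 the lowest of the three, with both of its steps beyond the scatter. Nothing available accounts for the difference between these groups.

The compounds shown do not separate the contribution of the ether oxygen from that of the nitrile on the benzyl ring. A plain benzyl ether, or a methoxy group or chlorine in place of the nitrile, would address that question.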